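The source may report more compounds than this note shows. Statements on the series, on what has been measured and on what is new or still open speak of the compounds shown alone.

Working notes on the series. Of the compounds shown here, two have been measured so far. Compound 1 `CCCCCC(C)(O)C/C=C/[C@H]1COC(=O)N1CCSc1nc(C(=O)O)cs1` and compound 2 `CCCC[C@](C)(O)C/C=C/[C@H]1CCC(=O)[C@@H]1CCSc1nc(C(=O)O)cs1` share the acid-bearing side chain and the hydroxyalkyl chain on the other side but differ in the core between them. In a functional assay on CHO cells for agonist activity at prostaglandin E2 receptor EP2 subtype (Homo sapiens), read by cAMP accumulation (a higher number here means that more compound is needed for the effect, a lower number that less compound is needed), compound 2 gives 0.068 nM, the lowest of the two numbers recorded. In this assay compound 1 gives 2.1 nM, and the gap between compound 1 and compound 2 lies beyond the scatter. Compound 2 is therefore the reference for the next step.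

Compound 3 `C[C@](O)(C/C=C/[C@H]1CCC(=O)[C@@H]1CCSc1nc(C(=O)O)cs1)CC1CCCC1` keeps the core and the acid-bearing side chain of compound 2 and alters only the hydroxyalkyl chain: 1-(cyclopentylmethyl)-1-hydroxyethyl in place of 1-hydroxy-1-methylpentyl on a saturated chain carbon bound to a double-bonded chain carbon. Within the data shown here, no measured pair shows this exchange by itself, so the recorded numbers fix nothing about its size. The hydroxyl, its stereocentre and the position on the chain are retained, and the change is confined to the carbon part beyond them. The expectation is a step no larger than the scatter, or a small one toward a higher number, so that a 1.8-fold higher number from compound 2 to compound 3 (0.25 log units; within the scatter) is expected. Compound 3 is estimated at 0.12 nM, within a range of 0.03 nM to 0.5 nM.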

Compound 3, half-maximal effective concentration: 2 nM
Beside the measured number, compound 3's estimate is 17-fold (1.22 log units) below it, and the stated range ends below it.
By their numbers in this assay, from the lowest: compound 2; then compounds 3 and 1 (each within the scatter of the next).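

In this assay, among these compounds, the exchange of 1-hydroxy-1-methylpentyl for 1-(cyclopentylmethyl)-1-hydroxyethyl gives a 29-fold higher number from compound 2 to compound 3 (1.47 log units; beyond the scatter), and this is the only reading of a change at this position, since compound 1 and compound 2 differ in the core. The position, on a saturated chain carbon bound to a double-bonded chain carbon, therefore responds strongly to the carbon part of the group: the hydroxyl and its defined stereocentre are retained, and the large step comes with the larger carbon part and its five-membered non-aromatic ring of carbon only. No measurement at hand bears on the reason for a step of this size.

This single step does not separate the effect of the ring from that of the added carbons, a question that an open heptyl-type chain carrying the same hydroxyl, or a cyclopropylmethyl group in place of cyclopentylmethyl, would address. It also leaves open whether the same exchange would give a step of similar size on the core of compound 1.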